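The source may report more compounds than this note shows. Statements on the series, on what has been measured and on what is new or still open speak of the compounds shown alone.

Compound 2 `Cc1oc(-c2ccc(Cl)c(Cl)c2)nc1CN1CCC(C(=O)NCCCN2C[C@H](C)C[C@H](C)C2)CC1` gives 3170 nM in an ADME assay on Huh7.5.1 cells (Homo sapiens) for cytotoxicity, read by ATP content, with a stated time of 48 h (a higher number here means that more compound is tolerated, a lower number that less compound is tolerated), and has the lowest number of the three measured compounds. Compound 3 `Cc1ccccc1-c1nc(CN2CCC(C(=O)NCCCN3CC4CCCC(C4)C3)CC2)c(C)o1` gives 10900 nM in this assay and compound 1 `Cc1ccccc1-c1nc(CN2CCC(C(=O)NCCCN3[C@H](C)CCC[C@@H]3C)CC2)c(C)o1` gives 21300 nM; compound 1 and compound 2 differ in two places, so their values are shown only side by side. Among the measured compounds shown here, the one measured step, a 2.0-fold lower number from compound 1 to compound 3 (0.29 log units; within the scatter), concerns the amine end of the chain and not the aryl group, so it does not bear directly on the change to compound 4 `COc1cccc(Cl)c1-c1nc(CN2CCC(C(=O)NCCCN3C[C@H](C)C[C@H](C)C3)CC2)c(C)o1`, which is 2-chloro-6-methoxyphenyl in place of 3,4-dichlorophenyl on an aromatic carbon. For the measured compounds named here, with no step touching the aryl group, the expectation is broad. Compound 4 is estimated at 6000 nM, between 2000 nM and 20000 nM, which would be a 1.9-fold higher number from compound 2 to compound 4 (0.28 log units; within the scatter).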

Compound 4, half-maximal cytotoxic concentration: 15800 nM
For compound 4 the middle estimate is 2.6-fold (0.42 log units) below the measured one, and the stated range covers the measured number.
By their numbers in this assay, from the lowest: compound 2; then compounds 3, 4 and 1 (each within the scatter of the next).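

At the aromatic carbon of the five-membered ring, with the amine end unchanged, 2-chloro-6-methoxyphenyl in place of 3,4-dichlorophenyl gives a 5.0-fold higher number from compound 2 to compound 4 (0.70 log units; beyond the scatter) in this assay. Among the compounds shown here, this is the first step read at this position, and it shows that the aryl group can shift this read-out beyond the scatter, which the one earlier step, at the amine end, did not do. No available evidence accounts for the size of this step.

Still open, on these data alone, is which part of the change carries the step: the chlorine placement or the methoxy group. An unsubstituted phenyl group on the same amine end would give a further reference point.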